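Halogen swap on the fused core of the series

The source may report more compounds than this note shows. Statements on the series, on what has been measured and on what is new or still open speak of the compounds shown alone.

Among the compounds with values here, compound 3 `Clc1nn(-c2ccc3ncccc3c2)c2nc(Nc3cnn(C4CCNCC4)c3)ncc12` gives 5 nM in an assay on isolated protein for inhibition of eIF-2-alpha kinase GCN2 (Homo sapiens) (a higher number here means a weaker inhibitor, a lower number a stronger inhibitor), the lowest of the three numbers so far; compound 2 `Cc1nn(-c2ccc3ncccc3c2)c2nc(Nc3cnn(C4CCNCC4)c3)ncc12` gives 11 nM and compound 1 `CCn1cc(Nc2ncc3c(C)nn(-c4ccc(OC)cc4)c3n2)cn1` gives 81 nM. Within the data shown here, the only step with a bearing here is a 2.2-fold lower number from compound 2 to compound 3 (0.34 log units; beyond the scatter), a modest change for a one-atom substituent swap at the same place. Compound 4 `Brc1nn(-c2ccc3ncccc3c2)c2nc(Nc3cnn(C4CCNCC4)c3)ncc12` carries bromo in place of chloro on an aromatic carbon. Among the measured compounds shown here, no measured step compares two halogens directly; the methyl-to-chloro step suggests that a further one-atom change at this position shifts this assay little. For compound 4 the expected step is therefore a 1.3-fold lower number from compound 3 to compound 4 (0.10 log units; within the scatter), within the scatter or slightly favourable. Compound 4 is estimated at 4 nM in this assay, with a range from 2 nM to 10 nM.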

Compound 4, half-maximal inhibitory concentration: 3 nM
For compound 4 the middle estimate is 1.3-fold (0.12 log units) above the measured one; the measured number falls inside the stated range.
By their numbers in this assay, from the lowest: compounds 4 and 3 (each within the scatter of the next); then compound 2; then compound 1.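

In this assay this position now has its first direct comparison of two halogens, a 1.7-fold lower number from compound 3 to compound 4 (0.22 log units; within the scatter), so bromo and chloro cannot be told apart here. Bromo also stands clear of methyl on the same aromatic carbon, with a 3.7-fold lower number from compound 2 to compound 4 (0.56 log units; beyond the scatter), so both halogens now lie beyond the scatter from methyl. The data shown offer no explanation for either step.

Still open, on these data alone, is how fluoro, iodo, an amine or a nitrile would fare at this carbon. Also open, as far as these compounds go, is whether these steps hold with a group other than quinolin-6-yl.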